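Methyl placement on the bicyclic core and growth inhibition

This account rests on a few compounds, and the source may have more. Where it says the series, first, only, none or still open, it means among the compounds named here.

Measured compounds:
- compound 1 `COc1ccc(-c2cc(O)c3cccnc3n2)cc1`
- compound 2 `COc1cccc(-c2cc(O)c3c(C)ccnc3n2)c1`
- compound 3 `COc1ccc(-c2cc(O)c3ccc(C)nc3n2)cc1`

In a functional assay on OVCAR-3 cells (Homo sapiens) (a higher number here means a weaker inhibitor of growth, a lower number a stronger inhibitor of growth), compound 1 gives 30200 nM. In this assay compound 2 gives 25.7 nM, the lowest of the two numbers. For compound 3 this assay reports > 100000 nM, which is a limit of the assay and not a number.

Compound 3 and compound 1 differ in one place: hydrogen in place of methyl on an aromatic carbon. The step is an at least 3.3-fold lower number from compound 3 to compound 1 (0.51 log units; beyond the scatter); its size can be given only as a bound because of the limit of > 100000 nM in this assay, at which 1 of the 3 values shown sits.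

Compound 2 and compound 3 have the same atoms joined differently; the difference between the two cores is not broken down here.

The unmeasured compound 4 `COc1cccc(-c2cc(O)c3cccnc3n2)c1` is related to compound 2 by the same kind of change, though at another place: hydrogen in place of methyl on an aromatic carbon. In the measured pair the methyl sat next to the ring nitrogen; here it sits ortho to a fused ring and opposite the ring nitrogen, so the earlier step is a guide to the kind of change, not to its size.

For compound 4 the step is expected to be a 16-fold higher number from compound 2 to compound 4 (1.19 log units; beyond the scatter) in this assay, resting on the direction of the measured step and on the wide gap between compound 2 at 25.7 nM and compound 1 at 30200 nM. Compound 4 is thus estimated at 400 nM, expected to lie between 40 nM and 8000 nM.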

Compound 4, concentration for 50% growth inhibition: 55 nM
Beside the measured number, compound 4's estimate is 7.3-fold (0.86 log units) above it, within the range that was stated.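

In this assay, replacing the methyl opposite the ring nitrogen with hydrogen gives a 2.1-fold higher number from compound 2 to compound 4 (0.33 log units; beyond the scatter), a modest step in which the methyl-bearing compound has the lower number. Carried from one core to the other, the same exchange of methyl for hydrogen keeps neither its direction nor its size: the same change on two cores in this assay, an at least 3.3-fold lower number (0.51 log units; beyond the scatter) from compound 3 to compound 1 and a 2.1-fold higher number (0.33 log units; beyond the scatter) from compound 2 to compound 4, at least 7.0-fold (0.85 log units) apart, beyond the scatter of two such steps

Two pairs cannot show whether the place of the methyl or the place of the methoxy group, which also differs between the pairs, decides this outcome, and the comparison gives only a bound, with compound 3 standing at a limit of the assay: the limit of > 100000 nM in this assay, at which 1 of the 4 values shown sits.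

Open, going by these compounds, is whether a methyl at the place it holds in compound 3 would also go with a higher number when the methoxy group sits as in compound 4, which would separate the two differences between the pairs. Also open, on these data alone, is how the place opposite the ring nitrogen responds to groups other than methyl, such as a longer chain, an amine or a carboxylic acid, and whether the modest step seen there extends to them.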